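Swapping the aryl cap on a sulfonamide series

A few compounds are considered here, and "the series" means these few. Any claim that something is new, unique, unknown or untested is made for them only; others in the source may bear on it.

Three compounds share one core: compound 1 `Cc1cccc(-n2cc(-c3ccccc3NS(=O)(=O)c3c[nH]c(=O)[nH]c3=O)nn2)c1`, compound 2 `O=c1[nH]cc(S(=O)(=O)Nc2ccccc2-c2cn(-c3ccccc3F)nn2)c(=O)[nH]1` and compound 3 `Cc1cccc(-n2cc(-c3cccc(NS(=O)(=O)c4c[nH]c(=O)[nH]c4=O)c3)nn2)c1`. In a functional assay on A549 cells (Homo sapiens) for antiproliferative activity, read by MTT assay, with a stated time of 24 h (on this read-out lower numbers stand for stronger inhibition and higher numbers for weaker inhibition), compound 1 gives 1870 nM, compound 2 gives 7370 nM and compound 3 gives 3550 nM. Compound 3 therefore has the second highest number of the three; its neighbour is compound 1, with a number that is lower but within the scatter, while compound 2 stands higher, beyond the scatter.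

Compound 4 `O=c1[nH]cc(S(=O)(=O)Nc2cccc(-c3cn(-c4ccc(Cl)cc4)nn3)c2)c(=O)[nH]1` has not been measured. It differs from compound 3 in one place: 4-chlorophenyl in place of 3-methylphenyl on an aromatic nitrogen. Among the compounds with values here, only one measured step bears on this: the change from compound 1 to compound 2, which also removed the 3-methylphenyl from the aromatic nitrogen and put a halogen-bearing phenyl in its place, gave a 3.9-fold higher number from compound 1 to compound 2 (0.60 log units; beyond the scatter). That halogen is a different one and sits at a different position of the phenyl, so the step is only a loose guide.

Given that single step, a modest rise in the number is expected for compound 4, probably near the edge of the scatter, as a 1.4-fold higher number from compound 3 to compound 4 (0.13 log units; within the scatter). The estimate for compound 4 in this assay is 4800 nM, with a range from 1900 nM to 12000 nM.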

Compound 4, half-maximal inhibitory concentration: 1730 nM
The estimate for compound 4 lay 2.8-fold (0.44 log units) above the measured number; the measured number lies below the stated range.
By their numbers in this assay, from the lowest: compounds 4, 1 and 3 (each within the scatter of the next, the first and the last beyond it); then compound 2.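

In this assay, putting 4-chlorophenyl in place of 3-methylphenyl on the aromatic nitrogen gives a 2.1-fold lower number from compound 3 to compound 4 (0.31 log units; beyond the scatter) and so shows that a halogen-bearing phenyl at this position need not weaken inhibition. The earlier swap to 2-fluorophenyl ran the other way, with a 3.9-fold higher number from compound 1 to compound 2 (0.60 log units; beyond the scatter) on the core of compound 1, so the same position can move the number in either direction; these two steps differ in the halogen, in where it sits on the phenyl and in the core that carries it, and the data cannot separate those differences. Nothing available here explains why the two steps point in opposite directions.

Still open, going by these compounds, is whether 4-chlorophenyl would also lower the number on the core of compound 1, and whether 2-fluorophenyl would raise it on the core of compound 3. Also open, on these data alone, is how a phenyl carrying an amine or a carboxylic acid would read at this position, which would show whether the result is tied to halogens at all.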